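A few compounds are considered here, and "the series" means these few. Any claim that something is new, unique, unknown or untested is made for them only; others in the source may bear on it.

Compound 1 `c1ccc2c(c1)CN[C@@H](CN(CCCCNCc1ccncc1)[C@H]1CCCc3cccnc31)C2`: in a functional assay on cells for agonist activity at C-X-C chemokine receptor type 4 (Homo sapiens), read by fluorescence and calcium flux, with a stated time of 90 s (a higher number here means that more compound is needed for the effect, a lower number that less compound is needed), compound 1 gives > 30000 nM, which is a limit of the assay and not a number.
Compound 2 `c1ccc2c(c1)CN[C@@H](CN(CCCCNCC1CCCCC1)[C@H]1CCCc3cccnc31)C2`: in this assay compound 2 gives > 30000 nM, again a limit.
Compound 3 `O=S1(=O)CCC(CNCCCCN(C[C@H]2Cc3ccccc3CN2)[C@H]2CCCc3cccnc32)CC1`: in this assay compound 3 gives > 30000 nM, also a limit.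

Compound 3 therefore stands where every measured member of the series stands: at the limit of > 30000 nM in this assay, at which 3 of the 3 values shown sit. None of the three pairwise comparisons carries information, since a step that the two limits leave unreadable from compound 1 to compound 2, a step that the two limits leave unreadable from compound 1 to compound 3 and a step that the two limits leave unreadable from compound 2 to compound 3 are all unreadable; the three groups tried on the saturated chain carbon bound to the amine nitrogen (pyridin-4-yl, cyclohexyl, 1,1-dioxothian-4-yl) cannot be told apart.

Compound 4 `c1ccc2c(c1)CN[C@@H](CN(CCCCNC1CCOCC1)[C@H]1CCCc3cccnc31)C2` is the next variation. The change from compound 3 is oxan-4-yl in place of (1,1-dioxothian-4-yl)methyl on an amine nitrogen; the ring is brought one bond closer to the amine nitrogen and is smaller and carries fewer acceptors. For the measured compounds named here, no measured step bears on this change with a readable size, so there is no basis for expecting a move in this assay beyond the scatter in either direction. The working expectation is that compound 4 also returns a limit, with the estimated step from compound 3 to compound 4 being a step that the limit leaves unreadable from compound 3 to compound 4. Compound 4 is accordingly estimated at 40000 nM, with a range from 12000 nM to 150000 nM.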

Compound 4, half-maximal effective concentration: > 30000 nM
Compound 4 was reported as a limit (the forecaster's own chance of this, stated with the estimate: 80%); the middle value lies beyond the limit too.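

In this assay compound 4 gives > 30000 nM, a limit and not a number. Its steps from compound 1, compound 2 and compound 3 cannot be read, and the series stays as before: the limit of > 30000 nM in this assay, at which 4 of the 4 values shown sit.

The compounds shown leave open whether any group on this amine nitrogen gives a readable value in this assay.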